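Moving the bromine on the phenyl group of compound 1

The compounds below may be only part of what the source reports. "The series", "measured", "known", "first", "only" and "open" are said of these compounds alone.

In a functional assay on DU-145 cells (Homo sapiens) for antiproliferative activity, read by MTT assay, with a stated time of 48 h (on this read-out lower numbers stand for stronger inhibition and higher numbers for weaker inhibition), compound 1 (`C/C(=C\CC/C(C)=C/CC[C@@H]1[C@@]2(C)CCC(=O)C(C)(C)[C@H]2CC[C@@]1(C)O)CC/C=C(\C)C(=O)OCc1cn(-c2ccccc2Br)nn1`) gives > 150000 nM as a limit of the assay, not a number. Compound 2 (`C/C(=C\CC/C(C)=C/CC[C@@H]1[C@@]2(C)CCC(=O)C(C)(C)[C@H]2CC[C@@]1(C)O)CC/C=C(\C)C(=O)OCc1cn(-c2ccc(F)c(Cl)c2)nn1`) gives > 150000 nM as a limit too. Compound 3 (`C/C(=C\CC/C(C)=C/CC[C@@H]1[C@@]2(C)CCC(=O)C(C)(C)[C@H]2CC[C@@]1(C)O)CC/C=C(\C)C(=O)OCc1cn(C[C@@H]2O[C@H](n3ccc(=O)[nH]c3=O)C[C@H]2O)nn1`) reads 33100 nM in this assay as a true number. Compound 1 therefore has no number of its own and stands with the limit of > 150000 nM in this assay, at which 2 of the 3 values shown sit, as the only description of its place.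

Compound 4 (`C/C(=C\CC/C(C)=C/CC[C@@H]1[C@@]2(C)CCC(=O)C(C)(C)[C@H]2CC[C@@]1(C)O)CC/C=C(\C)C(=O)OCc1cn(-c2cccc(Br)c2)nn1`) differs from compound 1 in one place: 3-bromophenyl in place of 2-bromophenyl on an aromatic nitrogen.

Among the measured compounds shown here, the one measured step at that aromatic nitrogen is a step that the two limits leave unreadable from compound 1 to compound 2 and it offers no size to carry over. No step beyond the scatter is expected in this assay for this change, and no direction can be assigned, because the limit of > 150000 nM in this assay, at which 2 of the 3 values shown sit, takes in both compound 1 and compound 2. The estimated step is a number no higher from compound 1 to compound 4 (the limit leaves the size open) in this reading. Compound 4 is expected at 150000 nM (estimated range 60000 nM to 300000 nM).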

Compound 4, half-maximal inhibitory concentration: > 150000 nM
Compound 4 ended at the assay's limit; the forecaster's own chance of this, stated with the estimate: 70%; the middle value lies on the limit itself.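

No new step can be read among compound 1, compound 2 and compound 4, because all three stand at a single assay limit: the limit of > 150000 nM in this assay, at which 3 of the 4 values shown sit.

The compounds shown leave open how the 2-bromophenyl, 3-bromophenyl and 3-chloro-4-fluorophenyl compounds truly rank in this assay.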